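The source may hold more compounds than are shown below. What is called first, only, known or untested is meant among the compounds shown, and "the series" means these compounds.

Measured so far in an assay on U2OS cells for inhibition of secreted frizzled-related protein 1 (Homo sapiens), read by a luciferase reporter, with a stated time of 18 h; on this read-out higher numbers stand for an effect only at larger amounts of compound and lower numbers for an effect already at smaller amounts:
compound 1 `CN(C)c1ccc(C(=O)N2CCC(NS(=O)(=O)c3cc(S(=O)(=O)c4ccccc4)ccc3C(F)(F)F)CC2)cc1` gives 190 nM
compound 2 `O=C(O)c1cccc(S(=O)(=O)N2CCC(NS(=O)(=O)c3cc(S(=O)(=O)c4ccccc4)ccc3C(F)(F)F)CC2)c1` gives 190 nM
compound 3 `O=C(O)c1ccc(S(=O)(=O)N2CCC(NS(=O)(=O)c3cc(S(=O)(=O)c4ccccc4)ccc3C(F)(F)F)CC2)cc1` gives 110 nM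

Compound 1 stands level with compound 2 at the digits shown, and its separation from compound 3 is within the scatter, so the three values are not ordered by these data. Compound 4 `O=C(CC1CCNCC1)N1CCC(NS(=O)(=O)c2cc(S(=O)(=O)c3ccccc3)ccc2C(F)(F)F)CC1` differs from compound 1 as follows: (piperidin-4-yl)methyl in place of 4-(dimethylamino)phenyl on a carbonyl carbon. The measured steps that touch the same place, the substituent on the amine nitrogen in a ring, are no change at the digits printed from compound 1 to compound 2 (within the scatter) and a 1.7-fold lower number from compound 1 to compound 3 (0.24 log units; within the scatter); both replace (4-(dimethylamino)phenyl)carbonyl with a (3-carboxyphenyl)sulfonyl or (4-carboxyphenyl)sulfonyl and neither moves the number beyond the scatter. The step of a 1.7-fold lower number from compound 2 to compound 3 (0.24 log units; within the scatter) between those two replacements is likewise within the scatter. None of these steps covers a non-aromatic ring in place of the aromatic one, so the expectation rests only on the observation that this place has so far tolerated change. The step of a 1.1-fold higher number from compound 1 to compound 4 (0.02 log units; within the scatter) is therefore expected to stay within the scatter. Compound 4 is estimated at 200 nM, with a range from 80 nM to 500 nM.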

Compound 4, half-maximal effective concentration: 210 nM
Compound 4: the middle estimate sits 1.1-fold (0.02 log units) below what was measured, and the stated range covers the measured number.
By their numbers in this assay, from the lowest: compounds 3, 1, 2 and 4 (each within the scatter of the next).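

With a 1.1-fold higher number from compound 1 to compound 4 (0.04 log units; within the scatter) in between, the swap of 4-(dimethylamino)phenyl for (piperidin-4-yl)methyl on this carbonyl carbon shows that a non-aromatic ring with a hydrogen-bond donor stays within the scatter, which the earlier aromatic substituents could not show. The comparisons with the two carboxylic acids read the same way, with a 1.1-fold higher number from compound 2 to compound 4 (0.04 log units; within the scatter) and a 1.9-fold higher number from compound 3 to compound 4 (0.28 log units; within the scatter) both within the scatter. Among these four compounds, then, neither an aromatic ring nor a carboxylic acid in this substituent is required for numbers at this level.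

Open, on these data alone, is whether this tolerance extends to a longer chain between the piperidine and the carbonyl, or to a methyl group on the piperidine nitrogen. As far as these compounds go, a morpholine ring in place of the piperidine is equally open. No supporting measurement bears on why this position tolerates these changes.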